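A few compounds are considered here, and "the series" means these few. Any claim that something is new, unique, unknown or untested is made for them only; others in the source may bear on it.

Measured so far in a functional assay on HCT-116 cells (Homo sapiens) for cytotoxicity, read by MTT assay, with a stated time of 48 h; on this read-out lower numbers stand for stronger inhibition and higher numbers for weaker inhibition:
- compound 1 `COc1ccc2[nH]c(-c3cccc(F)c3)cc(=O)c2c1OC` gives 1200 nM
- compound 2 `COc1ccc2[nH]c(-c3ccc(F)cc3)cc(=O)c2c1OC` gives > 20000 nM as a limit
- compound 3 `COc1ccc2[nH]c(-c3ccccc3F)cc(=O)c2c1O` gives 50 nM

Of the two actual numbers, the higher belongs to compound 1 at 1200 nM and the lower to compound 3 at 50 nM, a gap well beyond the usual scatter. The reading for compound 2 is a limit and not a number.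

Compound 4 `COc1ccc2[nH]c(-c3cccc(F)c3)cc(=O)c2c1O` differs from compound 1 in one place: hydrogen in place of methyl on an oxygen on an aromatic ring, with hydrogen in place of methyl on an oxygen on an aromatic ring, that is, methoxy to hydroxy.

Among the compounds with values here, the only measured single-place step is an at least 16-fold higher number from compound 1 to compound 2 (1.22 log units; beyond the scatter), which ends at a limit of > 20000 nM in this assay, at which 1 of the 3 values shown sits, and is large. It concerns 4-fluorophenyl in place of 3-fluorophenyl, so it shows that the series can move sharply but does not measure the methoxy to hydroxy change. The closest guide is compound 3 at 50 nM, which carries the hydroxy but has a different fluorophenyl, so its gap from compound 1 cannot be assigned to the hydroxy alone.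

A clear move toward lower numbers is therefore expected, with the expected step being a 10-fold lower number from compound 1 to compound 4 (1.00 log units; beyond the scatter) in this assay, beyond the scatter. Compound 4 is estimated at 120 nM, with an expected range from 25 nM to 700 nM in this read-out.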

Compound 4, half-maximal inhibitory concentration: 70 nM
Compound 4: the middle estimate sits 1.7-fold (0.23 log units) above what was measured, and the stated range covers the measured number.
By their numbers in this assay, from the lowest: compounds 3 and 4 (each within the scatter of the next); then compound 1. At a limit, above all of these: compound 2.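

In this assay, the methoxy to hydroxy change now has a direct measure with the 3-fluorophenyl held constant: a 17-fold lower number from compound 1 to compound 4 (1.23 log units; beyond the scatter), so replacing methyl with hydrogen on this oxygen on an aromatic ring produces a large shift toward lower numbers. Among the hydroxy compounds, the fluorophenyl change gives a 1.4-fold higher number from compound 3 to compound 4 (0.15 log units; within the scatter), so 3-fluorophenyl and 2-fluorophenyl cannot be told apart in this pair, unlike the large separation seen between the 3-fluorophenyl and 4-fluorophenyl methoxy compounds. Nothing measured here explains the gain from the hydroxy.

On these data alone, compound 2 gives > 20000 nM, which is a limit and not a number, so the effect of a hydroxy alongside the 4-fluorophenyl remains open. Also open, as far as these compounds go, is how this position responds to groups other than hydroxy and methoxy, such as an ethoxy group, an acetoxy group or an amine, and so whether the gain is specific to the hydroxy.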